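The source may hold more compounds than are shown below. What is called first, only, known or untested is meant among the compounds shown, and "the series" means these compounds.

Compound 1 `CCCSc1nc(N)nc2c1ncn2/C=C1/CC1(CO)CO`: > 20000 nM
Compound 2 `CCCCCCOc1nc(N)nc2c1ncn2/C=C1/CC1(CO)CO`: > 20000 nM

Both entries come from an ADME assay on BCBL1 cells (Homo sapiens) for cytotoxicity, with a stated time of 7 days; a lower number here means that less compound is tolerated, a higher number that more compound is tolerated. Compound 2 stands at > 20000 nM, which is a limit and not a number. Compound 1 gives > 20000 nM, also a limit. For the measured compounds named here, the one measured step, a step that the two limits leave unreadable from compound 1 to compound 2, therefore has no readable size. Compound 3 `Nc1nc(SCc2ccccc2)c2ncn(/C=C3/CC3(CO)CO)c2n1` differs from compound 2 by benzylsulfanyl in place of hexyloxy on an aromatic carbon, with benzylsulfanyl in place of hexyloxy. Going by the values given here, the only guide is the limit of > 20000 nM in this assay, at which 2 of the 2 values shown sit, so no step beyond the scatter is expected in this assay, and another limit is likely. The expected step is a step that the limit leaves unreadable from compound 2 to compound 3. For compound 3 the estimate is 22000 nM, with an expected range of 9000 nM to 50000 nM.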

Compound 3, half-maximal cytotoxic concentration: > 20000 nM
Compound 3: no number, only a limit (the forecaster's own chance of this, stated with the estimate: 75%); the middle value does not contradict the limit.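

In this assay, for the compounds shown here, compound 3 gives > 20000 nM, a limit and not a number, so no step among compound 1, compound 2 and compound 3 can be read. The compounds shown leave open where the half-maximal cytotoxic concentration of each lies, with only this to go on: the limit of > 20000 nM in this assay, at which 3 of the 3 values shown sit.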